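One Carbon Longer on the Ester Chain

A few compounds are considered here, and "the series" means these few. Any claim that something is new, unique, unknown or untested is made for them only; others in the source may bear on it.

Compound 1 `CCCCOC(=O)CCC(=O)N1CCN(CCCOc2cc3c(Nc4ccc(F)c(Cl)c4)ncnc3cc2OC)CC1`: 36.9%
Compound 2 `CCCCCCCCCCCCCCOC(=O)CCC(=O)N1CCN(CCCOc2cc3c(Nc4ccc(F)c(Cl)c4)ncnc3cc2OC)CC1`: 77.2%

Both compounds were tested in a functional assay on A549 cells (Homo sapiens) for cytotoxicity, read by MTT assay, with a stated time of 24 h, tested at 80 uM; on this read-out lower numbers stand for a stronger effect and higher numbers for a weaker effect at the one concentration tested. Within the data shown here, compound 2 stands highest of the two numbers, and the only measured step is a number 40.3 percentage points higher from compound 1 to compound 2 (beyond the scatter). Compound 3 `CCCCCCCCCCCCCCCOC(=O)CCC(=O)N1CCN(CCCOc2cc3c(Nc4ccc(F)c(Cl)c4)ncnc3cc2OC)CC1` differs from compound 2 by methyl in place of hydrogen on a saturated chain carbon, ten or more bonds along the chain from an oxygen next to a carbonyl group. That single measured step bears on the present change, yet it came from adding a far longer piece to the same chain, whereas here only one methyl enters. A shift no larger than the scatter is therefore expected. Compound 3 is estimated at 78%, within 65% to 91%. The expected step is a number 0.8 percentage points higher from compound 2 to compound 3 (within the scatter).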

Compound 3, a percentage reported as activity, at one concentration (the size of the read-out at that concentration, not a potency): 81.1%
Beside the measured number, compound 3's estimate is 3.1 percentage points below it; the measured number falls inside the stated range.
By their numbers in this assay, from the lowest: compound 1; then compounds 2 and 3 (each within the scatter of the next).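

In this assay, the added methyl on a saturated chain carbon gives a change within the scatter (a number 3.9 percentage points higher from compound 2 to compound 3 (within the scatter)), so this long chain tolerates one more carbon. The full undecyl change still gives a large rise (a number 44.2 percentage points higher from compound 1 to compound 3 (beyond the scatter)), meaning weaker cytotoxicity. No available evidence explains these numbers. Hexyl and octyl esters remain open, so the chain length at which the number rises is unknown. As far as these compounds go, an ester chain carrying an amine or a carboxylic acid also remains open.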